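Bromo for Chloro on the Aryl Triazole Arm

A few compounds are considered here, and "the series" means these few. Any claim that something is new, unique, unknown or untested is made for them only; others in the source may bear on it.

compound 1: `Cc1c(O)ccc2c1[C@H](Cn1cc(-c3ccccc3)nn1)[C@@]13CC(=O)[C@@](C)(CC[C@@H]21)C3` — in a functional assay on A549 cells (Homo sapiens) for cytotoxicity, read by MTT assay, with a stated time of 4 days (on this read-out higher numbers stand for weaker inhibition and lower numbers for stronger inhibition), compound 1 gives only a limit, > 20000 nM
compound 2: `C=C1C[C@]23C[C@@]1(O)CC[C@@H]2c1cccc(C)c1[C@@H]3Cn1cc(-c2ccc(OC)cc2)nn1` — in this assay compound 2 gives only a limit, > 20000 nM
compound 3: `C=C1C[C@]23C[C@@]1(O)CC[C@@H]2c1cccc(C)c1[C@@H]3Cn1cc(-c2ccc(Cl)cc2)nn1` — in this assay compound 3 gives only a limit, > 20000 nM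

All three measured compounds stop at the same limit of this assay, and none of them yields a number; this is summed up by the limit of > 20000 nM in this assay, at which 3 of the 3 values shown sit. Compound 3 therefore stands nowhere in particular on a scale: it is at the limit, like the other two. For the measured compounds named here, the only single-point comparison among the measured set, a step that the two limits leave unreadable from compound 2 to compound 3, cannot be read, since both ends are limits.

Compound 4 is `C=C1C[C@]23C[C@@]1(O)CC[C@@H]2c1cccc(C)c1[C@@H]3Cn1cc(-c2ccc(Br)cc2)nn1`. It differs from compound 3 by bromo in place of chloro on an aromatic carbon. Going by the values given here, no measured step bears on this exchange; the nearest one, from methoxy to chloro, is itself unreadable. With every measured compound at the limit and no readable step to build on, compound 4 is expected to behave like compound 3, and its step from compound 3, a step that the limit leaves unreadable from compound 3 to compound 4, is expected to be none beyond the scatter. Compound 4 is thus estimated at 30000 nM, with a range from 10000 nM to 100000 nM, most probably reported again only as a limit.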

Compound 4, half-maximal inhibitory concentration: > 20000 nM
Compound 4: a limit, no number; the forecaster's own chance of this, stated with the estimate: 85%; the middle value lies beyond the limit too.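

In this assay compound 4 gives > 20000 nM, a limit and not a number. The steps to compound 4 from compound 2 and compound 3 therefore cannot be read. The compounds shown leave open whether any exchange on the aryl triazole arm changes cytotoxicity.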